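Working notes: nitro in place of chloro

A few compounds are considered here, and "the series" means these few. Any claim that something is new, unique, unknown or untested is made for them only; others in the source may bear on it.

Measured in a toxicity assay on Vero cells (Chlorocebus sabaeus) for cytotoxicity, read by colorimetric assay and MTT assay, with a stated time of 72 h; on this read-out lower numbers stand for higher toxicity in this test and higher numbers for lower toxicity in this test:
Compound 1 `Nc1cccc(F)c1C(=O)NNc1cccc(F)c1`: 1360000 nM
Compound 2 `Nc1cccc(F)c1C(=O)NNc1cccc(Cl)c1`: > 1800000 nM

For compound 2 the entry > 1800000 nM is a limit of the assay and not a number. The next change leads to compound 3 `Nc1cccc(F)c1C(=O)NNc1cccc([N+](=O)[O-])c1`, with nitro in place of chloro on an aromatic carbon, meta to a large group: nitro in place of chloro on an aromatic carbon.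

Among the compounds with values here, one measured step bears on this change, chloro in place of fluoro on an aromatic carbon. It amounts to an at least 1.3-fold higher number from compound 1 to compound 2 (0.12 log units; that floor lies within the scatter). That step gives only a floor and involves neither the nitro group nor any measured compound carrying it, so it offers little guidance on direction. Within the data shown here, the only firm number is that of compound 1, at 1360000 nM. No step beyond the scatter is therefore expected in this assay, and neither direction is favoured. The expected change is an at least 1.0-fold lower number from compound 2 to compound 3 (0.02 log units; that floor lies within the scatter). Compound 3 is expected at 1700000 nM, with an estimated range of 700000 nM to 3500000 nM.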

Compound 3, half-maximal cytotoxic concentration: 1300000 nM
Estimate against measurement, compound 3: 1.3-fold (0.12 log units) above; measured number inside the range.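

In this assay the nitro group at this position, meta to a large group, gives a second firm number, and that number does not separate from the one for fluoro (a 1.0-fold lower number from compound 1 to compound 3 (0.02 log units; within the scatter)). Fluoro and nitro differ in heavy atoms and hydrogen-bond acceptors as counted, yet across these two firm numbers that difference leaves the read-out within the scatter, while the step from chloro reads only as a floor, also within the scatter (an at least 1.3-fold lower number from compound 2 to compound 3 (0.14 log units; that floor lies within the scatter)). Compound 2 holds a limit of the assay and not a number, and this sets the reading of that floor: the limit of > 1800000 nM in this assay, at which 1 of the 3 values shown sits.

Whether chloro really parts from fluoro and nitro at this position stays open, as only a floor exists for it and no step shown here passes the scatter. Also open is whether an amine, a carboxylic acid or a methoxy group at this position would move the number in this assay beyond the scatter, or whether the read-out stays as flat there as it does across the groups shown.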